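Swapping a Methoxybenzyl Arm for Cyclopropyl

This account rests on a few compounds, and the source may have more. Where it says the series, first, only, none or still open, it means among the compounds named here.

Within the data shown here, in a physicochemical assay for lipophilicity (on this read-out higher numbers stand for higher lipophilicity and lower numbers for lower lipophilicity), compound 1 `COc1ccc(CNCc2c(-c3nnc(SC(C)C)n3-c3ccccc3)n(C)c3ccc(F)cc23)cc1` gives 6.42, the top of the three numbers measured so far. Compound 2 `COc1ccc(CNCc2c(-c3nnc(SC(C)C)n3-c3ccccc3)n(C)c3ccccc23)cc1` gives 6.27, and the change a number 0.15 log units lower from compound 1 to compound 2 (within the scatter) stays within the scatter of the method. Compound 3 `CC(C)Sc1nnc(-c2c(CNCCN3CCCC3)c3ccccc3n2C)n1-c1ccccc1` gives 4.83, reached through the change a number 1.44 log units lower from compound 2 to compound 3 (beyond the scatter). The unmeasured compound 4 `CC(C)Sc1nnc(-c2c(CNC3CC3)c3cc(F)ccc3n2C)n1-c1ccccc1` differs from compound 1 by cyclopropyl in place of 4-methoxybenzyl on an amine nitrogen. Among the measured compounds shown here, no measured step covers exactly this exchange; the nearest, the large step between compound 2 and compound 3, also removes the 4-methoxyphenyl group, so a drop of broadly similar size is expected here. Compound 4 is therefore estimated at 5.1, with a range from 4.5 to 5.7. The expected step is a number 1.32 log units lower from compound 1 to compound 4 (beyond the scatter).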

Compound 4, partition coefficient: 4.97
Compound 4: middle estimate off by 0.13 log units, on the high side; low and high end bracket the measured number.
By their numbers in this assay, from the lowest: compounds 3 and 4 (each within the scatter of the next); then compounds 2 and 1 (each within the scatter of the next).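

Exchanging 4-methoxybenzyl for cyclopropyl on the amine nitrogen gives a number 1.45 log units lower from compound 1 to compound 4 (beyond the scatter) in this assay with the rest of the molecule unchanged. The earlier large step brought in a pyrrolidin-1-yl group with a nitrogen of its own, whereas the entering cyclopropyl is carbon only, so a large step on this arm does not need a new nitrogen.

On these data alone, whether losing the methoxy group, the aromatic ring or the heavy atoms counts most stays open, and a plain benzyl group or a straight butyl chain on the same nitrogen would help separate these. Nothing given here offers a reason for the size of this step.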